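Chloro for Methyl: From Compound 3 to Compound 4

The source may report more compounds than this note shows. Statements on the series, on what has been measured and on what is new or still open speak of the compounds shown alone.

Compound 1 `O=C(/C=C/CCCCCCc1ccccc1)N1CCCC1`: > 100000 nM in a functional assay on PANC-1 cells (Homo sapiens) for cytotoxicity, read by WST assay, with a stated time of 24 h (on this read-out lower numbers stand for stronger inhibition and higher numbers for weaker inhibition), a limit of the assay.
Compound 2 `O=C(CCCCCCCc1ccccc1)N1CCCCC1`: > 100000 nM in this assay, a limit of the assay.
Compound 3 `Cc1ccc(CCCCCCCCC(=O)N2CCCCC2)cc1`: > 100000 nM in this assay, a limit of the assay.

None of the three measured compounds gives a number in this assay. Compound 3 stands only at a limit, and the same holds for the other two values shown, as the limit of > 100000 nM in this assay, at which 3 of the 3 values shown sit, records. Every value is a limit. Among the measured compounds shown here, no step between measured compounds can be stated, and compound 3 cannot be ranked against compound 1 or compound 2.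

The unmeasured compound 4 `O=C(CCCCCCCCc1ccc(Cl)cc1)N1CCCCC1` differs from compound 3 in one place: chloro in place of methyl on an aromatic carbon. For the measured compounds named here, nothing among the measured compounds shows what this exchange does in this assay, so no step beyond the usual scatter is expected in either direction. Compound 4 is therefore expected to remain at or near the limit, with a step that the limit leaves unreadable from compound 3 to compound 4 from compound 3 expected. The estimate for compound 4 in this assay is 150000 nM, within a range from 50000 nM to 500000 nM, and it is most likely that the assay again reports only a limit.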

Compound 4, half-maximal inhibitory concentration: 65500 nM
Compound 4: the middle estimate sits 2.3-fold (0.36 log units) above what was measured; the range from low to high includes it.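

In this assay compound 4 is the only one of the compounds shown that returns a number, 65500 nM, which places chloro, on an aromatic carbon and para to a large group, as the one exchange here that brings a value inside the range the assay can read. Compound 3 stands at > 100000 nM, and that value is a limit of the assay. Read against it, the exchange gives an at least 1.5-fold lower number from compound 3 to compound 4 (0.18 log units; that floor lies within the scatter), which is a floor and not a measured size, because the value of compound 3 is only a limit: the limit of > 100000 nM in this assay, at which 3 of the 4 values shown sit.

How far compound 3 truly lies from compound 4 stays unknown, so the compounds shown cannot say whether chloro in place of methyl changes the read-out by more than the usual variation between repeats. Also open, going by these compounds, is whether fluoro, bromo, methoxy or a carboxylic acid in the same place would give a number in this assay, and whether the 4-chlorophenyl group would do so on a shorter or a longer chain.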